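Hydroxymethyl for sulfamoyl on a shared core

A few compounds are considered here, and "the series" means these few. Any claim that something is new, unique, unknown or untested is made for them only; others in the source may bear on it.

Compound 1 `Cc1cc(CCC#N)cc(C)c1Oc1cc(Nc2ccc(C#N)cc2)c(N)cc1S(N)(=O)=O` gives 11100 nM in an ADME assay on TZM cells (Homo sapiens) for cytotoxicity, read by XTT assay, with a stated time of 4 days; on this read-out lower numbers stand for higher toxicity in this test and higher numbers for lower toxicity in this test.
Compound 2 `Cc1cc(/C=C/C#N)cc(C)c1Oc1cc(Nc2ccc(C#N)cc2)c(N)cc1C(=O)O` gives 14900 nM in this assay.
Compound 3 `Cc1cc(/C=C/C#N)cc(C)c1Oc1cc(Nc2ccc(C#N)cc2)c(N)cc1[N+](=O)[O-]` gives > 24400 nM in this assay, which is a limit of the assay rather than a number.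

Among these three, compound 1 and compound 2 sit within the usual scatter of each other, so no order can be drawn between them. Compound 3 supplies a limit only (the limit of > 24400 nM in this assay, at which 1 of the 3 values shown sits). For the measured compounds named here, the single measured step between neighbours, an at least 1.6-fold higher number from compound 2 to compound 3 (0.21 log units; that floor lies within the scatter), concerns nitro in place of carboxy and has a floor that lies inside the scatter. Compound 4 `Cc1cc(CCC#N)cc(C)c1Oc1cc(Nc2ccc(C#N)cc2)c(N)cc1CO` differs from compound 1 by hydroxymethyl in place of sulfamoyl on an aromatic carbon. Going by the values given here, neither group in that exchange appears in any measured step, so no measured step bears directly on it; the one step available is small at its floor and gives no reason to expect movement in this assay beyond the scatter in either direction. Compound 4 is therefore expected to give 12000 nM, between 5000 nM and 30000 nM, in this assay. The expected step of a 1.1-fold higher number from compound 1 to compound 4 (0.03 log units; within the scatter) is thus estimated as no change beyond the scatter.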

Compound 4, half-maximal cytotoxic concentration: > 23800 nM
Compound 4: no number, only a limit (the forecaster's own chance of this, stated with the estimate: 20%); at least 1.9-fold (0.29 log units) between middle value and limit.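

On the shared core, the position ortho to a large group and para to a (4-cyanophenyl)amino group now gives the first step shown that clears the scatter in this assay: an at least 2.1-fold higher number from compound 1 to compound 4 (0.33 log units; beyond the scatter). Hydroxymethyl in place of sulfamoyl therefore moves this read-out towards lower toxicity in this test, a shift the earlier compounds could not show, since their only step had a floor inside the scatter. The value of compound 4 is a limit of the assay and not a number, so the step gives only a floor: the limit of > 23800 nM in this assay, at which 1 of the 4 values shown sits.

From the compounds shown here alone, how far compound 4 lies past that limit remains open. So does whether a carboxylic acid, an amine or a longer chain such as hydroxyethyl at this position on the core of compound 1 would read the same way.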